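The compounds below may be only part of what the source reports. "The series", "measured", "known", "first", "only" and "open" are said of these compounds alone.

Measured compounds:
compound 1 `O=C(O)c1cc(-c2cccc(COc3ccc4c(=O)n(C5CC5)sc4c3)c2)ccc1Cl` with 100%;
compound 2 `Cc1ccc(C(=O)O)cc1-c1cccc(COc2ccc3c(c2)CN(C2CCCC2)C3=O)c1` with 100%;
compound 3 `Cc1ccc(C(=O)O)cc1-c1cccc(COc2ccc3c(=O)n(C4CCCC4)sc3c2)c1` with 100%.

All three were tested in an ADME assay on a cell-free system (plasma, Rattus norvegicus) for metabolic stability, read by LC-MS, with a stated time of 1 h, at 37 degrees C, tested at 100 uM; on this read-out lower numbers stand for a less stable compound and higher numbers for a more stable compound. Compound 2 stands level with compound 1 and compound 3 at the digits reported; neither neighbour differs from it beyond the scatter, and the three values leave no room for an order among them. Compound 4 `O=C1c2ccc(OCc3cccc(-c4ccccc4)c3)cc2CN1C1CCCC1` has not been measured in this assay. It differs from compound 2 in one place: phenyl in place of 5-carboxy-2-methylphenyl on an aromatic carbon. Given that compound 2 gives 100%, the step from compound 2 to compound 4 is expected to be none beyond the scatter, a number 3 percentage points lower from compound 2 to compound 4 (within the scatter). For compound 4 the expected value in this assay is 97%, in the range from 85% to 100%.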

Compound 4, percent of the compound remaining: 95%
Beside the measured number, compound 4's estimate is 2 percentage points above it; the measured number falls inside the stated range.
By their numbers in this assay, from the lowest: compounds 4, 1, 2 and 3 (each within the scatter of the next).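

In this assay, putting phenyl in place of 5-carboxy-2-methylphenyl on this aromatic carbon gives a number 5 percentage points lower from compound 2 to compound 4 (within the scatter). Compound 4 is the only compound shown without the carboxylic acid, so at this position the read-out does not depend on that group being present. No measurement shown gives a reason for this result. From the compounds shown here alone, what an amine or a longer chain on this phenyl ring would give remains open, as does whether the same change would hold on the core of compound 3.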